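Adding a Methoxy to the Core of Compound 2

A few compounds are considered here, and "the series" means these few. Any claim that something is new, unique, unknown or untested is made for them only; others in the source may bear on it.

Compound 2 `COc1ccc([C@@H]2Sc3ccccc3N(CCN(C)C)C(=O)[C@@H]2C)cc1` was tested in an assay on muscle tissue (Cavia porcellus) for displacement of a labelled ligand from Voltage-dependent L-type calcium channel subunit alpha-1S (Homo sapiens) (on this read-out lower numbers stand for stronger inhibition and higher numbers for weaker inhibition), where compound 2 gives 540 nM. Among the two compounds measured so far, that number is the highest. Within the data shown here, the other measured compound, compound 1 `COc1ccc([C@@H]2Sc3cc(OC)ccc3N(CCN(C)C)C(=O)[C@@H]2OC(C)=O)cc1`, differs from compound 2 in more than one place; in this assay compound 1 gives 42 nM, and the two values lie beyond the scatter of each other, but no single step between them can be drawn.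

Compound 3 `COc1ccc([C@@H]2Sc3cc(OC)ccc3N(CCN(C)C)C(=O)[C@@H]2C)cc1` has not been measured. It differs from compound 2 in one place: methoxy in place of hydrogen on an aromatic carbon. Among the measured compounds shown here, no measured pair shows this change by itself, so its effect can only be estimated. Compound 1 carries the same methoxy and gives the lower number, yet it also differs elsewhere, so that comparison cannot be separated into parts. Compound 3 is expected to come in with a lower number than compound 2. The step of a 3.4-fold lower number from compound 2 to compound 3 (0.53 log units; beyond the scatter) is expected to be a moderate gain, beyond the scatter. Compound 3 is therefore estimated at 160 nM in this assay, with a range from 50 nM to 500 nM.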

Compound 3, inhibition constant: 85 nM
Estimate against measurement, compound 3: 1.9-fold (0.27 log units) above, within the range that was stated.
By their numbers in this assay, from the lowest: compound 1; then compound 3; then compound 2.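

With methoxy in place of hydrogen on an aromatic carbon, this assay now gives a reading for this change by itself: a 6.4-fold lower number from compound 2 to compound 3 (0.80 log units; beyond the scatter) is a modest gain, beyond the scatter, at the position meta to a fused ring and para to a fused ring. Compound 3 also connects compound 1 through a single change, since methyl in place of acetoxy on a saturated ring carbon gives a 2.0-fold higher number from compound 1 to compound 3 (0.31 log units; beyond the scatter) and is likewise printed as modest and beyond the scatter. The path from compound 2 to compound 1 can therefore be followed through compound 3 in two steps, and both of them run toward a lower number in that direction. The data at hand offer no explanation for either step.

Still open, as far as these compounds go, is whether another group on the same aromatic carbon, such as a chlorine atom, a hydroxyl or an ethoxy, would lower the number as methoxy does. From the compounds shown here alone, it is equally open how a hydroxyl or a longer ester such as propionyloxy would compare with acetoxy and methyl on the saturated ring carbon.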